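This account rests on a few compounds, and the source may have more. Where it says the series, first, only, none or still open, it means among the compounds named here.

Among the compounds with values here, in a functional assay on MDA-MB-231 cells (Homo sapiens) for inhibition, read by CCK-8 assay, with a stated time of 48 h (on this read-out higher numbers stand for weaker inhibition of growth and lower numbers for stronger inhibition of growth), compound 3 `Cc1ccc(CNc2nc(Nc3ccc(N4CCN(C)CC4)cn3)ncc2Cl)cc1` gives 18600 nM, the only actual number among the compounds tested so far. Compound 1 `Cc1ccccc1Nc1nc(NCc2ccco2)ncc1Cl` gives > 100000 nM, which is a limit of the assay and not a number. Compound 2 `Cc1ccccc1Nc1nc(Nc2ccc(N3CCCCC3)cn2)ncc1Cl` gives > 100000 nM, which is also a limit.

The next compound to be tested is compound 4 `CN1CCN(c2ccc(Nc3ncc(Cl)c(NCc4ccco4)n3)nc2)CC1`. It differs from compound 3 in one place, with furan-2-yl in place of 4-methylphenyl on a saturated chain carbon bound to a nitrogen on an aromatic ring. The swap replaces one aromatic ring with a smaller one that contains a hetero atom.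

Within the data shown here, no pair of measured compounds isolates this change, so the data offer no direct guide to its size. The one firm reference point is compound 3 at 18600 nM, and the other reference is the limit of > 100000 nM in this assay, at which 2 of the 3 values shown sit. With so little to go on, a moderate shift toward weaker inhibition of growth seems the most reasonable expectation in this assay, and a change within the usual scatter remains possible. The estimated step is a 1.6-fold higher number from compound 3 to compound 4 (0.21 log units; within the scatter). For compound 4 the expected value is 30000 nM, with an estimated range from 9000 nM to 95000 nM.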

Compound 4, concentration for 50% growth inhibition: 11000 nM
The estimate for compound 4 lay 2.7-fold (0.44 log units) above the measured number; low and high end bracket the measured number.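

Within the data shown here, until now, no pair of compounds showed what this position tolerates. In this assay, the pair gives the first such reading, a 1.7-fold lower number from compound 3 to compound 4 (0.23 log units; within the scatter), so compound 3 and compound 4 cannot be told apart on this read-out, even though 4-methylphenyl, a six-membered ring of carbon only, gives way to furan-2-yl, a five-membered ring with fewer heavy atoms, one oxygen and one hydrogen-bond acceptor. On a saturated chain carbon bound to a nitrogen on an aromatic ring, then, this swap of one aromatic ring for another leaves growth inhibition within the usual scatter, and both compounds give actual numbers, which cannot be said of the whole set: the limit of > 100000 nM in this assay, at which 2 of the 4 values shown sit.

Among these compounds, this single pair compares only two aromatic rings, so it remains open whether the same place would accept a group without an aromatic ring, such as cyclohexyl, or one carrying a charged function, such as a carboxylic acid or a dimethylamino group at the end of a longer chain. It also cannot show whether the same tolerance would hold with a different group elsewhere on the shared core.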